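The source may report more compounds than this note shows. Statements on the series, on what has been measured and on what is new or still open speak of the compounds shown alone.

In an ADME assay on HEK293 cells for displacement of a labelled ligand from 5-hydroxytryptamine receptor 7 (Homo sapiens), read by radioligand binding, with a stated time of 1 h (a higher number here means a weaker inhibitor, a lower number a stronger inhibitor), compound 1 `O=C1c2ccccc2S(=O)(=O)N1CCCCCCN1CCN(c2ccccc2Cl)CC1` gives 120 nM, compound 2 `O=C1c2ccccc2S(=O)(=O)N1CCCCCCN1CCN(c2cccc(Cl)c2)CC1` gives 233 nM, and compound 3 `O=C1c2ccccc2S(=O)(=O)N1CCCCCCN1CCN(c2cccc(Cl)c2Cl)CC1` gives 119 nM. Compound 2 holds the highest of the three numbers, yet its gaps to the other two are within the scatter: a 1.9-fold higher number from compound 1 to compound 2 (0.29 log units; within the scatter) and a 2.0-fold lower number from compound 2 to compound 3 (0.29 log units; within the scatter). Likewise a 1.0-fold lower number from compound 1 to compound 3 (0.00 log units; within the scatter). So far, changing the chloro pattern on the phenyl, whether by relocating it or by adding a second chloro, has left this assay flat.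

Compound 4 `COc1cccc(N2CCN(CCCCCCN3C(=O)c4ccccc4S3(=O)=O)CC2)c1` is the next member, differing from compound 2 as follows: methoxy in place of chloro on an aromatic carbon. Going by the values given here, no measured step exchanges a chloro for a methoxy, so the only guidance is the flatness just described, in which all three phenyl variations sit within the scatter of each other. Among the compounds with values here, on that ground no step beyond the scatter is expected from compound 2 to compound 4 in this assay; the estimated step is a 1.1-fold higher number from compound 2 to compound 4 (0.03 log units; within the scatter), with the range kept wide since the exchange itself has no precedent in this set. Compound 4 is therefore expected to give 250 nM in this assay, between 90 nM and 700 nM.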

Compound 4, inhibition constant: 305 nM
For compound 4 the middle estimate is 1.2-fold (0.09 log units) below the measured one; the range from low to high includes it.
By their numbers in this assay, from the lowest: compounds 3, 1, 2 and 4 (each within the scatter of the next, the first and the last beyond it).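

In this assay, going by these compounds alone, the first exchange of the group itself at this aromatic carbon, rather than a relocated or added chloro, stays within the scatter (a 1.3-fold higher number from compound 2 to compound 4 (0.12 log units; within the scatter)), so a methoxy, with its extra heavy atom and hydrogen-bond acceptor, is tolerated here about as well as a chloro. The series also now shows its first steps beyond the scatter, both modest and both to the 3-methoxyphenyl compound: one from the 2,3-dichlorophenyl compound (a 2.6-fold higher number from compound 3 to compound 4 (0.41 log units; beyond the scatter)) and one from the 2-chlorophenyl compound (a 2.5-fold higher number from compound 1 to compound 4 (0.41 log units; beyond the scatter)), while compound 2 remains within the scatter of all three others, so the four compounds form a shallow gradient rather than two separate groups. Nothing at hand bears on why these numbers fall as they do.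

Still open, as far as these compounds go, is whether the response stays this shallow with a hydroxy, a trifluoromethyl or a nitrile on the same aromatic carbon, or whether one of these would give a larger step from compound 2. Also open, from the compounds shown here alone, is whether a methoxy together with a second chloro on the phenyl would give numbers closer to those of compound 1 and compound 3.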